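The source may hold more compounds than are shown below. What is called first, only, known or untested is meant among the compounds shown, and "the series" means these compounds.

Compound 2 `Fc1ccc(-c2n[nH]c3c2CCNCC3)cc1` carries a fluoro group on the shared core. In an assay on cells for displacement of a labelled ligand from 5-hydroxytryptamine receptor 5A (Homo sapiens), read by scintillation counting, with a stated time of 1.5 h (on this read-out lower numbers stand for stronger inhibition and higher numbers for weaker inhibition), compound 2 gives > 10000 nM, which is a limit of the assay rather than a number. Compound 1 `Cc1ccc(-c2n[nH]c3c2CCNCC3)cc1`, with methyl instead, gives > 10000 nM, also a limit. The step that the two limits leave unreadable from compound 1 to compound 2 cannot be read because the limit of > 10000 nM in this assay, at which 2 of the 3 values shown sit, is where both values sit. Compound 3 `Cc1ccc(-c2noc3c2CCNCC3)cc1`, with a different core, gives 1140 nM. Compound 4 `Clc1ccc(-c2n[nH]c3c2CCNCC3)cc1` differs from compound 2 by chloro in place of fluoro on an aromatic carbon. For the measured compounds named here, no measured step shows how such a change moves this read-out, so compound 4 is expected to remain weak. The estimate for compound 4 is 10000 nM, within 3000 nM to 30000 nM. The expected step of a number no higher from compound 2 to compound 4 (the limit leaves the size open) is none beyond the scatter.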

Compound 4, inhibition constant: > 10000 nM
Compound 4 was reported as a limit; the forecaster's own chance of this, stated with the estimate: 60%; the middle value sits exactly at the limit.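

In this assay, for the compounds shown here, no step among compound 1, compound 2 and compound 4 can be read, because all three sit at the same limit: the limit of > 10000 nM in this assay, at which 3 of the 4 values shown sit.
From the compounds shown here alone, whether methyl, fluoro and chloro on the shared core differ at all on this read-out stays open.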